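The source may report more compounds than this note shows. Statements on the series, on what has been measured and on what is new or still open speak of the compounds shown alone.

Measured so far:

Compound 1 `Cn1cc(CNS(=O)(=O)c2ccccc2Nc2cc(-c3ccc4ccn(C)c4c3)c3nccnc3c2)cn1` — 2 ug/mL
Compound 2 `Cn1ccc2ccc(-c3cc(Nc4ccccc4S(=O)(=O)NCC4CCOCC4)cc4nccnc34)cc21` — 2 ug/mL
Compound 3 `CC(=O)N1CCC(NC(=O)c2ccncc2Nc2cc(-c3ccc4ccn(C)c4c3)c3nccnc3c2)CC1` — 213 ug/mL

In a physicochemical assay for solubility, read by spectrophotometry, measured as kinetic solubility, at pH 8, tested at 500 uM (on this read-out higher numbers stand for higher solubility and lower numbers for lower solubility), compound 3 stands highest of the three numbers, far beyond the scatter from compound 1 and from compound 2. Compound 4 `CN1CCC(CNC(=O)c2ccncc2Nc2cc(-c3ccc4ccn(C)c4c3)c3nccnc3c2)C1` is built from compound 3 by one change: (1-methylpyrrolidin-3-yl)methyl in place of 1-acetylpiperidin-4-yl on an amide-type nitrogen. Within the data shown here, the only step measured so far, no change at the digits printed from compound 1 to compound 2 (within the scatter), concerns a group on a sulfonamide nitrogen in a different part of the molecule and does not bear directly on the change from compound 3 to compound 4. Among the measured compounds shown here, compounds 1 and 2 differ from compound 3 in more than one place, so their values show only that the shared core can sit at either end of the range seen here. For the measured compounds named here, with no step at the amide-type nitrogen to lean on, the expectation for compound 4 is that it stays close to compound 3, with a step of a 1.1-fold lower number from compound 3 to compound 4 (0.03 log units; within the scatter) in this assay. Compound 4 is therefore estimated at 200 ug/mL, within a range of 90 ug/mL to 240 ug/mL.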

Compound 4, solubility: 246 ug/mL
The estimate for compound 4 lay 1.2-fold (0.09 log units) below the measured number; the measured number lies above the stated range.
By their numbers in this assay, from the lowest: compounds 1 and 2 (each within the scatter of the next); then compounds 3 and 4 (each within the scatter of the next).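

In this assay the swap at the amide-type nitrogen gives a 1.2-fold higher number from compound 3 to compound 4 (0.06 log units; within the scatter), so this position accepts either group with no real difference in the read-out. The two groups are not close relatives: 1-acetylpiperidin-4-yl has a six-membered non-aromatic ring and an oxygen, while (1-methylpyrrolidin-3-yl)methyl has a five-membered non-aromatic ring and no oxygen, yet compound 3 and compound 4 cannot be told apart here. No measurement shown gives a reason for this outcome.

How the read-out would respond to a carboxylic acid or an open alkyl chain on the amide-type nitrogen remains an open question. Going by these compounds, whether the same swap would behave alike on a different core also stays open.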